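From tert-butyl to phenyl: an unmeasured step

The source may report more compounds than this note shows. Statements on the series, on what has been measured and on what is new or still open speak of the compounds shown alone.

Compound 1 `CC(C)(C)OC(=O)N1CCC[C@H]1C(=O)N1CCC(NS(=O)(=O)c2cc(S(=O)(=O)c3ccccc3)ccc2C(F)(F)F)CC1`: 25000 nM
Compound 2 `CC(=O)N1CCC[C@H]1C(=O)N1CCC(NS(=O)(=O)c2cc(S(=O)(=O)c3ccccc3)ccc2C(F)(F)F)CC1`: 12500 nM
Compound 3 `CC(C)(C)NC(=O)N1CCC[C@H]1C(=O)N1CCC(NS(=O)(=O)c2cc(S(=O)(=O)c3ccccc3)ccc2C(F)(F)F)CC1`: 50000 nM

In a physicochemical assay for solubility (a higher number here means a more soluble compound, a lower number a less soluble compound), compound 3 gives 50000 nM. It stands close to one neighbour (a 2.0-fold higher number from compound 1 to compound 3 (0.30 log units; within the scatter)) and clearly apart from the other (a 4.0-fold higher number from compound 2 to compound 3 (0.60 log units; beyond the scatter)).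

Compound 4 `O=C([C@@H]1CCCN1C(=O)Nc1ccccc1)N1CCC(NS(=O)(=O)c2cc(S(=O)(=O)c3ccccc3)ccc2C(F)(F)F)CC1` carries phenyl in place of tert-butyl on an amide-type nitrogen. Among the compounds with values here, no measured compound has phenyl here, so the evidence is indirect. The three measured steps all swap the group on a carbonyl carbon. Two stay within the scatter (a 2.0-fold lower number from compound 1 to compound 2 (0.30 log units; within the scatter); a 2.0-fold higher number from compound 1 to compound 3 (0.30 log units; within the scatter)), and the largest is only modest (a 4.0-fold higher number from compound 2 to compound 3 (0.60 log units; beyond the scatter)). A step of similar modest size therefore seems reasonable. Within the data shown here, no measured compound stands beyond the scatter above compound 3, so a lower number is the likelier direction, though three compounds cannot settle this. The expected change is a 2.5-fold lower number from compound 3 to compound 4 (0.40 log units; beyond the scatter). The estimate for compound 4 is 20000 nM, with an expected range from 6000 nM to 50000 nM.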

Compound 4, solubility: 25000 nM
Estimate against measurement, compound 4: 1.3-fold (0.10 log units) below; the measured number falls inside the stated range.
By their numbers in this assay, from the lowest: compounds 2, 1, 4 and 3 (each within the scatter of the next, the first and the last beyond it).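

Compound 4 places phenyl, a six-membered aromatic ring of carbon only, on the amide-type nitrogen, and in this assay the swap from tert-butyl reads as a 2.0-fold lower number from compound 3 to compound 4 (0.30 log units; within the scatter) here. The comparisons by way of the carbonyl carbon read the same way in this assay, with a 2.0-fold higher number from compound 2 to compound 4 (0.30 log units; within the scatter) for anilino in place of methyl and no change at the digits printed from compound 1 to compound 4 (within the scatter) for anilino in place of tert-butoxy. A ring at this place therefore leaves compound 4 within the scatter of all three earlier compounds, even though compound 2 and compound 3 stand beyond the scatter of each other.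

No measurement shown here accounts for this result. On these data alone, how a phenyl carrying a carboxylic acid or an amine, or a longer chain in place of the ring, would read in this assay remains open.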